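A Second Chloro on Compound 2

A few compounds are considered here, and "the series" means these few. Any claim that something is new, unique, unknown or untested is made for them only; others in the source may bear on it.

In a functional assay on MCF7 cells (Homo sapiens) for antiproliferative activity, read by sulforhodamine B assay, with a stated time of 72 h (on this read-out higher numbers stand for weaker inhibition and lower numbers for stronger inhibition), compound 1 (`CC(C)=CCc1cc(C(=O)/C=C/c2csc3ccccc23)c(O)cc1O`) gives 7400 nM as its measured value. Compound 2 (`O=C(/C=C/c1cc2ccccc2s1)c1cc(Cl)ccc1O`) reads > 10000 nM and this is a limit of the assay, not a number. Compound 3 (`O=C(/C=C/c1cc2ccccc2s1)c1cc(Br)ccc1O`) reads > 10000 nM and this too is a limit, not a number. Compound 2 thus stands at the limit of > 10000 nM in this assay, at which 2 of the 3 values shown sit, and offers no exact value to start from.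

Compound 4 (`O=C(/C=C/c1cc2ccccc2s1)c1cc(Cl)cc(Cl)c1O`) differs from compound 2 by one change (chloro in place of hydrogen on an aromatic carbon): chloro in place of hydrogen on an aromatic carbon, ortho to a hydroxy group and meta to a chloro group. The nearest measured change is a step that the two limits leave unreadable from compound 2 to compound 3 with bromo in place of chloro on an aromatic carbon, and it gives no size to carry over. For the measured compounds named here, no measured step puts a chloro where a hydrogen stood. With compound 2 at > 10000 nM as a limit, no clear step in either direction is expected in this assay and compound 4 is expected to stay close to it. A report of only a limit is quite possible for compound 4. The expected step (a step that the limit leaves unreadable from compound 2 to compound 4) is a rough estimate only. For compound 4 the estimated value is 12000 nM with an expected range from 5000 nM to 30000 nM on this read-out.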

Compound 4, half-maximal inhibitory concentration: 9900 nM
The estimate for compound 4 lay 1.2-fold (0.08 log units) above the measured number; measured number inside the range.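

Adding a chloro group on the aromatic carbon ortho to a hydroxy group gives the first exact number for this core, as compound 4 reads 9900 nM in this assay. Compound 2 and compound 3, which carry a single halogen, give only limits. Compound 2 reads > 10000 nM, which is a limit and not a number. Chloro in place of hydrogen on an aromatic carbon thus gives a number no higher from compound 2 to compound 4 (the limit leaves the size open). The step from chloro to bromo cannot be read, because the starting point offers no exact value: the limit of > 10000 nM in this assay, at which 2 of the 4 values shown sit.

The compounds shown thus establish only that a second chloro at this position is compatible with a measurable effect on these cells, not how much it contributes. They leave open whether a smaller or a different group at the same place, such as an amine, a methoxy group or a carboxylic acid, would give a lower number, and whether a bromo group there would behave as the chloro group does.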